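One Trifluoromethyl Group Added to Compound 2

The source may hold more compounds than are shown below. What is called first, only, known or untested is meant among the compounds shown, and "the series" means these compounds.

Of the compounds shown here, two have been measured in a functional assay on NIH3T3 cells for agonist activity at Urotensin-2 receptor (Homo sapiens), with a stated time of 5 days; a higher number here means a larger maximal response, a lower number a smaller maximal response. Compound 1 `CN(C)CCC(NC(=O)/C=C/c1ccc(C(F)(F)F)cc1)c1ccc2ccccc2c1` gives 117%. Compound 2 `Cc1ccc(C(CCN(C)C)NC(=O)/C=C/c2ccccc2)cc1` gives 97%, the lower of the two numbers, and its gap to compound 1 lies beyond the scatter. Compound 3 `Cc1ccc(C(CCN(C)C)NC(=O)/C=C/c2ccc(C(F)(F)F)cc2)cc1` differs from compound 2 in one place: trifluoromethyl in place of hydrogen on an aromatic carbon. Compound 1 also carries a trifluoromethyl group and shows the higher number, although it differs from compound 2 elsewhere as well. The step from compound 2 to compound 3 is therefore expected to be a modest rise, a number 11 percentage points higher from compound 2 to compound 3 (beyond the scatter). Compound 3 is estimated at 108%, within 90% to 125%.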

Compound 3, largest response reached (reported as efficacy), in percent of the reference or control that the assay uses: 96%
The estimate for compound 3 lay 12 percentage points above the measured number; measured number inside the range.
By their numbers in this assay, from the lowest: compounds 3 and 2 (each within the scatter of the next); then compound 1.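

In this assay, trifluoromethyl on the aromatic carbon para to a large group makes no readable difference to the maximal response, with a number 1 percentage points lower from compound 2 to compound 3 (within the scatter) for this change. Among these compounds, with trifluoromethyl present in both compounds, 4-methylphenyl in place of naphthalen-2-yl gives a number 21 percentage points lower from compound 1 to compound 3 (beyond the scatter) and is the only structural change in that step. Nothing available explains either result. From the compounds shown here alone, it remains open whether naphthalen-2-yl gives the same step without trifluoromethyl. Also open, going by these compounds, is how a nitrile or methoxy group would behave at the position that carries trifluoromethyl.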